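Swapping the sulfamoylphenyl for a fluoropyridyl on the thiazole

A few compounds are considered here, and "the series" means these few. Any claim that something is new, unique, unknown or untested is made for them only; others in the source may bear on it.

Compound 1 `O=C(O)Cc1sc(C(c2ccccc2)c2ccc(Cl)cc2)nc1-c1ccc(F)cc1`: in an in vitro functional assay on HEK285-7 cells for antagonist activity at prostaglandin D2 receptor 2 (Homo sapiens), read by BRET and beta-arrestin recruitment (on this read-out higher numbers stand for weaker inhibition and lower numbers for stronger inhibition), compound 1 gives 79 nM.
Compound 2 `NS(=O)(=O)c1ccc(-c2nc(C(c3ccc(F)cc3)c3ccc(F)cc3)sc2CC(=O)O)cc1`: in this assay compound 2 reaches only the limit > 100000 nM.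
Compound 3 `NS(=O)(=O)c1cccc(-c2nc(C(c3ccc(F)cc3)c3ccc(F)cc3)sc2CC(=O)O)c1`: in this assay compound 3 gives 710 nM.

Compound 3 holds the highest of the two numbers that were actually determined; compound 1 sits lower, and the gap between them lies beyond the scatter. Compound 2 yields no number at all, only the limit (the limit of > 100000 nM in this assay, at which 1 of the 3 values shown sits). Going by the values given here, the one measured step with a single change, an at least 140-fold lower number from compound 2 to compound 3 (2.14 log units; beyond the scatter), shows that moving the sulfamoyl group on the aromatic ring has a large effect.

Compound 4 `O=C(O)Cc1sc(C(c2ccc(F)cc2)c2ccc(F)cc2)nc1-c1ccnc(F)c1` differs from compound 3 by 2-fluoropyridin-4-yl in place of 3-sulfamoylphenyl on an aromatic carbon. Among the compounds with values here, no measured step replaces the sulfamoylphenyl group as a whole, so the expectation rests on compound 1, whose aryl ring without a sulfamoyl group gives 79 nM while its other groups also differ. Compound 4 is therefore expected to give 250 nM in this assay, with a range from 50 nM to 1500 nM, an expected step of a 2.8-fold lower number from compound 3 to compound 4 (0.45 log units; beyond the scatter).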

Compound 4, half-maximal inhibitory concentration: 4.7 nM
Estimate against measurement, compound 4: 53-fold (1.73 log units) above; the whole stated range lies above it.
By their numbers in this assay, from the lowest: compound 4; then compound 1; then compound 3. At a limit, above all of these: compound 2.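

Exchanging the whole 3-sulfamoylphenyl for 2-fluoropyridin-4-yl at this aromatic carbon, with the rest of the molecule unchanged, brings a 150-fold lower number from compound 3 to compound 4 (2.18 log units; beyond the scatter); the earlier compounds had shown a large effect at this position only for moving the sulfamoyl group around its ring. Measured against the other sulfamoyl isomer, the same exchange brings an at least 21000-fold lower number from compound 2 to compound 4 (4.32 log units; beyond the scatter). Compound 2 stands at a limit of the assay, so that second step is a bound and not a measured size: the limit of > 100000 nM in this assay, at which 1 of the 4 values shown sits.

The compounds shown do not separate what the ring nitrogen and the fluorine of 2-fluoropyridin-4-yl each contribute, or the loss of the sulfamoyl group from the change of ring. Going by these compounds, it remains open whether a plain pyridin-4-yl or a 2-chloropyridin-4-yl at this carbon would hold the number of compound 4.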